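This account rests on a few compounds, and the source may have more. Where it says the series, first, only, none or still open, it means among the compounds named here.

Measured in a physicochemical assay for lipophilicity, read by HPLC, in phosphate buffer, measured as octanol-water partition, at pH 7.4; on this read-out lower numbers stand for lower lipophilicity and higher numbers for higher lipophilicity:

Compound 1, `CCC(=O)N[C@@H](C)C(=O)N(C)/N=N/c1ccc(C#N)cc1`: 1.87
Compound 2, `CCCC(=O)N[C@@H](C)C(=O)N(C)/N=N/c1ccc(C#N)cc1`: 2.28
Compound 3, `CC(=O)N[C@@H](C)C(=O)N(C)/N=N/c1ccc(C#N)cc1`: 1.41

Of the three, compound 3 carries the lowest number in this assay. Its nearest neighbour is compound 1, reached by the step of a number 0.46 log units lower from compound 1 to compound 3 (beyond the scatter), and the furthest is compound 2, reached by the step of a number 0.87 log units lower from compound 2 to compound 3 (beyond the scatter). The remaining pair, compounds 1 and 2, is joined by the step of a number 0.41 log units higher from compound 1 to compound 2 (beyond the scatter). Each added chain carbon on the acyl group thus raised the number by a modest, similar amount, and both steps lay beyond the scatter.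

Compound 4, `C[C@H](NC(=O)c1ccccc1)C(=O)N(C)/N=N/c1ccc(C#N)cc1`, differs from compound 3 in one place: phenyl in place of methyl on a carbonyl carbon. This is a larger change than any of the measured steps, since several carbons enter at once and they form a ring rather than a chain. For the measured compounds named here, no measured pair here shows a ring entering, so the chain steps are the only guide. Taken together they point to a rise in this assay well beyond the scatter, and larger than the step from compound 2 to compound 3, though how far a ring carbon counts against a chain carbon is not shown by these compounds.

Compound 4 is therefore expected to give about 3 in this assay, in a range from 2.5 to 3.5. This expected change corresponds to the step of a number 1.59 log units higher from compound 3 to compound 4 (beyond the scatter).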

Compound 4, partition coefficient: 3.04
For compound 4 the middle estimate is 0.04 log units below the measured one; low and high end bracket the measured number.
By their numbers in this assay, from the lowest: compound 3; then compound 1; then compound 2; then compound 4.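

In this assay, the substituent on the carbonyl carbon had so far been seen only as a saturated chain, and compound 4 shows that a six-membered aromatic ring of carbon only can stand there too: the change from acetyl to benzoyl gives a number 1.63 log units higher from compound 3 to compound 4 (beyond the scatter) and is the largest single change among these compounds. For the compounds shown here, the ring also ranks above both longer chains, since phenyl in place of propyl gives a number 0.76 log units higher from compound 2 to compound 4 (beyond the scatter) and phenyl in place of ethyl gives a number 1.17 log units higher from compound 1 to compound 4 (beyond the scatter) so that the rise seen along the chains does not end at propyl and no compound goes against the order. Nothing shown here gives a measured reason for the size of these steps.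

On these data alone, whether the rise belongs to the aromatic ring or simply to the number of carbons entering stays open, and cyclohexyl or a hexyl chain on the same carbonyl carbon would separate the two. Also open, as far as these compounds go, is how far the number would move with an amine or a carboxylic acid on the phenyl ring, or with a methylene group placed between that ring and the carbonyl carbon.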